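Thiourea series: chloro added on the trifluoromethylphenyl ring

The source may hold more compounds than are shown below. What is called first, only, known or untested is meant among the compounds shown, and "the series" means these compounds.

Measured so far:
compound 1, `O=C(c1cc(Oc2cccc(NC(=S)Nc3ccc(F)c(F)c3)c2)ccn1)N1CCCC1`: 45600 nM
compound 2, `O=C(c1cc(Oc2cccc(NC(=S)Nc3cccc(C(F)(F)F)c3)c2)ccn1)N1CCCC1`: 27000 nM

In a functional assay on PC-3 cells (Homo sapiens) for cytotoxicity, read by MTT assay, with a stated time of 48 h (on this read-out higher numbers stand for weaker inhibition and lower numbers for stronger inhibition), compound 1 gives 45600 nM and compound 2 gives 27000 nM. Among the compounds with values here, the only step between them, a 1.7-fold lower number from compound 1 to compound 2 (0.23 log units; within the scatter), separates the two by nothing that can be called a difference. Compound 2 thus holds the lower of two numbers in this assay, with compound 1 within the scatter of it.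

Compound 3, `O=C(c1cc(Oc2cccc(NC(=S)Nc3ccc(Cl)c(C(F)(F)F)c3)c2)ccn1)N1CCCC1`, differs from compound 2 by chloro in place of hydrogen on an aromatic carbon. Within the data shown here, no measured step covers this change; the one step known, a 1.7-fold lower number from compound 1 to compound 2 (0.23 log units; within the scatter), swaps the whole ring substitution and stays within the scatter, so it gives no direction for a single added chloro. On that basis no step beyond the scatter is expected, with a slight lean to a lower number.

Compound 3 is therefore expected near 18000 nM in this assay, between 6000 nM and 50000 nM, which would mean an expected step of a 1.5-fold lower number from compound 2 to compound 3 (0.18 log units; within the scatter).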

Compound 3, half-maximal inhibitory concentration: 12100 nM
Compound 3: the middle estimate sits 1.5-fold (0.17 log units) above what was measured; measured number inside the range.
By their numbers in this assay, from the lowest: compound 3; then compounds 2 and 1 (each within the scatter of the next).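

In this assay, within the data shown here, chloro in place of hydrogen on the aromatic carbon ortho to a trifluoromethyl group gives the first single-place step to clear the scatter (a 2.2-fold lower number from compound 2 to compound 3 (0.35 log units; beyond the scatter)). Against the 3,4-difluorophenyl ring, the 4-chloro-3-(trifluoromethyl)phenyl ring gives a larger step (a 3.8-fold lower number from compound 1 to compound 3 (0.58 log units; beyond the scatter)), so compound 3 stands apart from both compound 1 and compound 2, though both steps are modest. No evidence in hand accounts for the shift seen with the added chloro.

As far as these compounds go, whether this step belongs to chloro itself or would appear with other groups on the same carbon stays open; a methoxy group, an amine or a carboxylic acid there would separate those readings. Also open, from the compounds shown here alone, is whether the step survives with a urea in place of the thiourea.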